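Swapping thiophen-3-yl for 2,5-dimethylthiophen-3-yl

The source may report more compounds than this note shows. Statements on the series, on what has been measured and on what is new or still open speak of the compounds shown alone.

Of the compounds shown here, two sharing one core have been measured so far in a functional assay on cells (Leukemia cell, Homo sapiens) for inhibition; a higher number here means a weaker inhibitor of growth, a lower number a stronger inhibitor of growth. Compound 1 (`N=C(N)N/N=C/c1c(-c2cc(Cl)sc2Cl)nc2n1CCS2`) gives 10200 nM, and compound 2 (`N=C(N)N/N=C/c1c(-c2ccsc2)nc2n1CCS2`) gives 19100 nM as its number. These two values lie within the scatter of each other, so compound 2 cannot be placed apart from compound 1.

Compound 3 (`Cc1cc(-c2nc3n(c2/C=N/NC(=N)N)CCS3)c(C)s1`) has not been measured. It carries 2,5-dimethylthiophen-3-yl in place of the thiophen-3-yl of compound 2, on an aromatic carbon of the core, and the counted difference is 2,5-dimethylthiophen-3-yl in place of thiophen-3-yl on an aromatic carbon. For the measured compounds named here, only one measured step bears on this change, the exchange of 2,5-dichlorothiophen-3-yl for thiophen-3-yl at the same place, which gave a 1.9-fold higher number from compound 1 to compound 2 (0.27 log units; within the scatter). Going by the values given here, that step stayed within the scatter, so no shift beyond the scatter is expected in this assay, although one step is thin evidence and no methyl-bearing compound has been measured yet. The expected change is a 1.4-fold lower number from compound 2 to compound 3 (0.13 log units; within the scatter), which would be no real difference. The estimated value for compound 3 is 14000 nM, with an expected range from 6000 nM to 32000 nM.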

Compound 3, concentration for 50% growth inhibition: 20900 nM
For compound 3 the middle estimate is 1.5-fold (0.17 log units) below the measured one; measured number inside the range.
By their numbers in this assay, from the lowest: compounds 1, 2 and 3 (each within the scatter of the next, the first and the last beyond it).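

For the compounds shown here, with the first methyl-bearing group at this place, 2,5-dimethylthiophen-3-yl in place of thiophen-3-yl gives a 1.1-fold higher number from compound 2 to compound 3 (0.04 log units; within the scatter), so in this assay the two methyl groups leave no difference that can be told from the scatter. Going by these compounds alone, the comparison of the two substituted groups shows something the earlier step did not: 2,5-dimethylthiophen-3-yl in place of 2,5-dichlorothiophen-3-yl gives a 2.0-fold higher number from compound 1 to compound 3 (0.31 log units; beyond the scatter), the first step at this place to pass the scatter, though only modestly. Methyl and chlorine on the thiophene ring are therefore not quite interchangeable in this test, yet compound 2, with neither, lies within the scatter of both compound 1 and compound 3. Nothing available explains this small gap.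

Going by these compounds, all three compounds carry a thiophene ring at this place, so how a phenyl or pyridyl ring there would compare remains open. Also open, on these data alone, is whether an amine or a carboxylic acid on the thiophene ring would move the number further than methyl or chlorine does.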